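The source may hold more compounds than are shown below. What is called first, only, known or untested is meant among the compounds shown, and "the series" means these compounds.

Compound 1 `COc1cccc2occ(Cc3coc4ccccc4c3=O)c(=O)c12` — in a functional assay on MDA-MB-231 cells (Homo sapiens) for antiproliferative activity, read by XTT assay (a lower number here means a stronger inhibitor, a higher number a weaker inhibitor), compound 1 reaches only > 10000 nM, which is a limit of the assay and not a number.
Compound 2 `O=c1c(Cc2coc3cccc(OCC4CCCCC4)c3c2=O)coc2cc(O)ccc12` — compound 2 gives 3220 nM.
Compound 3 `Cc1ccc2c(=O)c(Cc3coc4cccc(OCC5CCCCC5)c4c3=O)coc2c1` — compound 3 gives 3320 nM.

Compound 1 therefore stands apart from the other two: it is recorded only as the limit of > 10000 nM in this assay, at which 1 of the 3 values shown sits, whereas compounds 2 and 3 carry actual numbers and lie within the scatter of each other. Going by the values given here, the single measured step, a 1.0-fold higher number from compound 2 to compound 3 (0.01 log units; within the scatter), concerns a ring that carries no methoxy, and it shows that one substituent can replace another there without moving the readout.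

Compound 4 `O=c1c(Cc2coc3ccccc3c2=O)coc2ccccc12` is reached from compound 1 by hydrogen in place of methoxy on an aromatic carbon. Among the compounds with values here, no measured step removes a methoxy, so the measured step from compound 2 to compound 3 gives no guidance on the direction of this change. Within the data shown here, what remains is that compound 1 itself sits at a limit, and the only numbered compounds, 2 and 3, carry a cyclohexylmethoxy group that compound 4 lacks. Compound 4 is therefore expected to stay weak, with a step that the limit leaves unreadable from compound 1 to compound 4. For compound 4 the estimate in this assay is 15000 nM, within 5000 nM to 50000 nM, and a limit rather than a number is the more likely outcome.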

Compound 4, half-maximal inhibitory concentration: > 10000 nM
Compound 4: only a limit was reported; the forecaster's own chance of this, stated with the estimate: 60%; the middle value is on the limit's open side.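

Compound 1 and compound 4 share the same reading, which is a limit of the assay and not a number: the limit of > 10000 nM in this assay, at which 2 of the 4 values shown sit. Going by these compounds alone, no step can therefore be read between compound 1 and compound 4. The compounds shown leave open whether hydrogen in place of methoxy on an aromatic carbon changes the activity in this assay at all.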